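The source may report more compounds than this note shows. Statements on the series, on what has been measured and on what is new or still open speak of the compounds shown alone.

Working notes on the series. The shared core carries a benzyl group bearing a chloromethyl substituent, and the compounds differ in what sits on the core. Going by the values given here, compound 1 `ClCc1ccc(Cn2cnc3nc(Cl)nc(Cl)c32)cc1` provides the only number so far: in a functional assay on RXF 393 cells (Homo sapiens) for cytotoxicity, read by sulforhodamine B assay, with a stated time of 48 h (a lower number here means a stronger inhibitor of growth, a higher number a weaker inhibitor of growth), compound 1 gives 1650 nM. Compound 2 `Nc1nc(Cl)c2ncn(Cc3cccc(CCl)c3)c2n1` is the second entry, but in this assay compound 2 has "not determined" (no result reported), so no number exists for comparison and nothing can be said about it.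

Compound 3 `ClCc1ccc(Cn2cnc3ncnc(Cl)c32)cc1` is the next step from compound 1. The change is hydrogen in place of chloro on an aromatic carbon, in words hydrogen in place of chloro on an aromatic carbon. Among the compounds with values here, no step between two measured compounds is available, so the size of this step is open. The chloromethyl on the benzyl group is kept, and this is expected to be the main contributor, so the step from compound 1 to compound 3 is expected to be small, a 1.5-fold higher number from compound 1 to compound 3 (0.18 log units; within the scatter), with a slight loss of growth inhibition at most. Compound 3 is estimated at 2500 nM, range 800 nM to 8000 nM.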

Compound 3, concentration for 50% growth inhibition: 1650 nM
Estimate against measurement, compound 3: 1.5-fold (0.18 log units) above, and the stated range covers the measured number.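

In this assay the series now has its first readable step, no change at the digits printed from compound 1 to compound 3 (within the scatter), so in this pair the chloro group on the aromatic carbon between two ring nitrogen atoms can be replaced by hydrogen without a change beyond the scatter. From the compounds shown here alone, this shows that growth inhibition at this level does not depend on that chloro group in this pair, while the remaining chloro group and the chloromethyl on the benzyl group are kept in both compounds and remain untested. Nothing measured in the data offers an explanation for this result.

Going by these compounds, whether an amine or a methoxy group at the same position would leave the number equally unchanged stays open. Also open, on these data alone, is what happens on replacing the remaining chloro group or the chloromethyl group with hydrogen.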